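The compounds below may be only part of what the source reports. "The series", "measured", "known", "first", "only" and "open" are said of these compounds alone.

Working notes on the series. Within the data shown here, in a functional assay (trachea) for inhibition, with Cavia porcellus as the target (a lower number here means a stronger inhibitor, a higher number a weaker inhibitor), compound 1 (`CC1(C)c2ccc(C#N)cc2[C@@H](N2CCCCC2=O)[C@@H]1O`) gives 270 nM and compound 2 (`CC1(C)c2ccc(I)cc2[C@@H](N2CCCCC2=O)[C@@H]1O`) gives 300 nM as its value, which places compound 2 within the scatter of compound 1, the only other measured compound. Compound 3 (`CCc1ccc2c(c1)[C@@H](N1CCCCC1=O)[C@H](O)C2(C)C`) carries ethyl in place of iodo on an aromatic carbon, para to a fused ring: ethyl in place of iodo on an aromatic carbon is the full difference. Among the measured compounds shown here, one measured step bears on this change: a 1.1-fold higher number from compound 1 to compound 2 (0.05 log units; within the scatter) is iodo in place of cyano on an aromatic carbon, and it lies within the scatter. For the measured compounds named here, no measured compound carries ethyl, so the range stays wide. In this assay no step beyond the scatter is expected, and no direction is favoured. The expected change is no change at the digits printed from compound 2 to compound 3 (within the scatter) in this estimate. Compound 3 is estimated at 300 nM with an expected range from 120 nM to 750 nM in this assay.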

Compound 3, half-maximal inhibitory concentration: 2780 nM
The estimate for compound 3 lay 9.3-fold (0.97 log units) below the measured number; the measured number lies above the stated range.
By their numbers in this assay, from the lowest: compounds 1 and 2 (each within the scatter of the next); then compound 3.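

In this assay, the position para to a fused ring proves sensitive to the group it carries: ethyl gives a 9.3-fold higher number from compound 2 to compound 3 (0.97 log units; beyond the scatter) and a 10-fold higher number from compound 1 to compound 3 (1.01 log units; beyond the scatter). The earlier step between cyano and iodo therefore does not hold for every replacement, and among these three compounds, compound 3 alone stands apart as the weaker inhibitor. Nothing shown here accounts for the difference between ethyl and the other two groups.

As far as these compounds go, it remains open whether the weakening is particular to ethyl or extends to other carbon groups, such as methyl or a longer chain like propyl. The compounds shown also leave open how plain hydrogen, a methoxy group or an amine at this position would compare with cyano and iodo.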